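The compounds below may be only part of what the source reports. "The series", "measured", "known", "first", "only" and "open" are said of these compounds alone.

Measured so far: compound 1 `COC(=O)c1c(O)cc(C(C)C)c2cc(C)c(O)cc12` gives 4900 nM in a functional assay on microsomes from liver (Rattus norvegicus) for inhibition, with a stated time of 15 min; a lower number here means a stronger inhibitor, a higher number a weaker inhibitor; compound 2 `Cc1cc2c(C(C)C)ccc(C)c2cc1O` gives 4300 nM.

Compound 2 and compound 1 give numbers in this assay that lie within the usual scatter of each other, so on these two results neither stands apart. Compound 3 `Cc1cc2c(C(C)C)cc(O)c(C)c2cc1O` differs from compound 2 by a single change: hydroxy in place of hydrogen on an aromatic carbon. Going by the values given here, no step between measured compounds speaks to this change, so its effect is uncertain. Compound 3 is expected to give about 3500 nM, with a likely range from 1200 nM to 10000 nM. The step of a 1.2-fold lower number from compound 2 to compound 3 (0.09 log units; within the scatter) is thus expected to be small, within the scatter, leaning toward a somewhat lower number.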

Compound 3, half-maximal inhibitory concentration: 3800 nM
Beside the measured number, compound 3's estimate is 1.1-fold (0.04 log units) below it; measured number inside the range.
By their numbers in this assay, from the lowest: compounds 3, 2 and 1 (each within the scatter of the next).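

Placing hydroxy on this aromatic carbon, ortho to a methyl group and meta to an isopropyl group, gives a 1.1-fold lower number from compound 2 to compound 3 (0.05 log units; within the scatter) in this assay, so this position tolerates the new group without a clear shift in the number. Methyl in place of methoxycarbonyl on an aromatic carbon likewise gives a 1.3-fold lower number from compound 1 to compound 3 (0.11 log units; within the scatter), which also stays within the scatter. No measurement shown offers an explanation for these results. Going by these compounds, whether an amine or a carboxylic acid at this position would move the number beyond the scatter remains open.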